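From Methoxy to Amino at the Carbonyl Carbon

The source may hold more compounds than are shown below. What is called first, only, known or untested is meant among the compounds shown, and "the series" means these compounds.

Compound 1, `CC(=O)N/N=C/c1c(Cl)n(C2O[C@H](CO)[C@@H](O)[C@H]2O)c2cc(Cl)c(Cl)cc12`, gives 9000 nM in a functional assay on KB cells (Homo sapiens) for cytotoxicity, read by spectrophotometry and crystal violet staining; a lower number here means a stronger inhibitor, a higher number a weaker inhibitor.
Compound 2, `COC(=O)N/N=C/c1c(Cl)n(C2O[C@H](CO)[C@@H](O)[C@H]2O)c2cc(Cl)c(Cl)cc12`, gives 20000 nM in this assay.

Compound 2 has the higher of the two numbers: the change a 2.2-fold higher number from compound 1 to compound 2 (0.35 log units; beyond the scatter) is modest but beyond the scatter. Compound 3, `NC(=O)N/N=C/c1c(Cl)n(C2O[C@H](CO)[C@@H](O)[C@H]2O)c2cc(Cl)c(Cl)cc12`, differs from compound 2 by amino in place of methoxy on a carbonyl carbon. Going by the values given here, no measured step involves an amino group here; the only related step, a 2.2-fold higher number from compound 1 to compound 2 (0.35 log units; beyond the scatter), shows that swapping this substituent shifts the number only modestly. Compound 3 is therefore expected to land near compound 2, with the step of a 1.5-fold lower number from compound 2 to compound 3 (0.19 log units; within the scatter) likely within the scatter. The estimate for compound 3 in this assay is 13000 nM, ranging from 5000 nM to 35000 nM.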

Compound 3, half-maximal inhibitory concentration: > 100000 nM
Compound 3: only a limit was reported; the forecaster's own chance of this, stated with the estimate: 10%; middle value at least 7.6-fold (0.88 log units) away from the limit.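

In this assay, the group on this carbonyl carbon matters more than the first swap suggested: amino in place of methoxy gives an at least 5.0-fold higher number from compound 2 to compound 3 (0.69 log units; beyond the scatter), and amino in place of methyl gives an at least 11-fold higher number from compound 1 to compound 3 (1.04 log units; beyond the scatter). For compound 3, > 100000 nM is a limit of the assay and not a number. Methyl and methoxy leave measurable values on the same core, while amino does not.

As far as these compounds go, the true size of both new steps stays open. So does whether a methylamino or dimethylamino group at this carbon would read like amino or like methoxy.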